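Aryl change from compound 2 to compound 3

This account rests on a few compounds, and the source may have more. Where it says the series, first, only, none or still open, it means among the compounds named here.

Measured so far:
- compound 1 `Clc1ccccc1-c1cc(-c2cnn(C3CCNCC3)c2)on1`, 38%
- compound 2 `Fc1cccc(-c2cc(-c3cnn(C4CCNCC4)c3)on2)c1Cl`, 47%

In an assay on a protein complex for positive allosteric modulation of Neuronal acetylcholine receptor; alpha4/beta2 (Homo sapiens) (a lower number here means a smaller maximal response, a higher number a larger maximal response), compound 1 gives 38%, and compound 2 gives 47%. For the measured compounds named here, compound 2 holds the highest of the two numbers, but its only neighbour, compound 1, lies within the scatter of it, so the two read as equal for practical purposes. Going by the values given here, the single step between measured compounds, a number 9 percentage points higher from compound 1 to compound 2 (within the scatter), does not rise above the scatter.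

Compound 3 `Clc1cccc(Cl)c1-c1cc(-c2cnn(C3CCNCC3)c2)on1` differs from compound 2 by 2,6-dichlorophenyl in place of 2-chloro-3-fluorophenyl on an aromatic carbon. Among the compounds with values here, no measured step covers this change: the one step in hand exchanged hydrogen for fluoro, a different change at a different group, and it was itself within the scatter. It therefore gives no guide to the size or direction of the present step beyond showing that the series has so far moved little. The working expectation for compound 3 in this assay is a step of a number 4 percentage points lower from compound 2 to compound 3 (within the scatter), that is none beyond the scatter. The estimated value for compound 3 is 43%, with a range from 25% to 62%.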

Compound 3, largest response reached (reported as efficacy), in percent of the reference or control that the assay uses: 73%
Compound 3: the middle estimate sits 30 percentage points below what was measured; measured number above the stated range.
By their numbers in this assay, from the lowest: compounds 1 and 2 (each within the scatter of the next); then compound 3.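

At this position, on an aromatic carbon next to the ring nitrogen, the aryl group can move the response beyond the scatter in this assay: 2,6-dichlorophenyl in place of 2-chloro-3-fluorophenyl gives a number 26 percentage points higher from compound 2 to compound 3 (beyond the scatter), a change of a kind the earlier fluoro step did not show. Chloro in place of hydrogen on the aryl ring gives a number 35 percentage points higher from compound 1 to compound 3 (beyond the scatter), so among these three compounds a second halogen raises the maximal response beyond the scatter only in the 2,6-dichlorophenyl arrangement, while the fluoro of compound 2 stays within the scatter of compound 1. Nothing at hand accounts for this rise.

Since the added fluoro and the added chloro differ both in the atom and in where they sit on the ring, these compounds do not separate the effect of the halogen from the effect of its place. As far as these compounds go, whether the second chlorine can give way to a methyl, methoxy or trifluoromethyl group with the response held, and whether the rise in this assay comes with any change in potency, remains open.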